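Homologous amide chain in the nitro methylsulfonyl series

This account rests on a few compounds, and the source may have more. Where it says the series, first, only, none or still open, it means among the compounds named here.

Compound 3, `CC(C)N(C(=O)CCNC(=O)c1ccc(S(C)(=O)=O)c([N+](=O)[O-])c1)C(C)C`, stands at the assay limit: in an ADME assay on HepG2 cells (Homo sapiens) for cytotoxicity, read by CellTiter-Glo and ATP content, with a stated time of 72 h (a higher number here means that more compound is needed for the effect, a lower number that less compound is needed), compound 3 gives > 27000 nM, which is a limit and not a number. The two other compounds also end at a limit. Compound 1, `CS(=O)(=O)c1ccc(C(=O)NCCC(=O)N2CCCCC2)cc1[N+](=O)[O-]`, gives > 27000 nM in this assay, a limit. Compound 2, `CC1CCN(C(=O)CCCNC(=O)c2ccc(S(C)(=O)=O)c([N+](=O)[O-])c2)CC1`, gives > 27000 nM in this assay, a limit. Within the data shown here, the only step between measured compounds, a step that the two limits leave unreadable from compound 1 to compound 3, is therefore unreadable.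

Compound 4, `CS(=O)(=O)c1ccc(C(=O)NCCCC(=O)N2CCCCC2)cc1[N+](=O)[O-]`, differs from compound 3 by ((piperidin-1-yl)carbonyl)methyl in place of diisopropylcarbamoyl on a saturated chain carbon, two bonds along the chain from an amide-type nitrogen. Among the measured compounds shown here, no measured step bears readably on this change, because of the limit of > 27000 nM in this assay, at which 3 of the 3 values shown sit; nothing beyond the scatter can be expected in this assay. Compound 4 is thus expected at the limit as well, estimated at 40000 nM with a range of 20000 nM to 100000 nM. The expected step that the limit leaves unreadable from compound 3 to compound 4 is none beyond the scatter.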

Compound 4, half-maximal effective concentration: > 27000 nM
Compound 4 ended at the assay's limit; the forecaster's own chance of this, stated with the estimate: 90%; the middle value does not contradict the limit.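

No step from compound 1, compound 2 or compound 3 to compound 4 can be read, because all four compounds end at a limit: the limit of > 27000 nM in this assay, at which 4 of the 4 values shown sit.

As far as these compounds go, whether the amide chain or the amine group changes the half-maximal effective concentration in this assay stays open.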